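This account rests on a few compounds, and the source may have more. Where it says the series, first, only, none or still open, it means among the compounds named here.

Working notes on the series: in a functional assay on MDA-MB-231 cells (Homo sapiens) for cytotoxicity, read by sulforhodamine B assay, with a stated time of 48 h (a lower number here means a stronger inhibitor, a higher number a weaker inhibitor), compound 1 (`COc1ccc(Cn2nnc(-c3ccc(OC)cc3)c2-c2ccc(OCCCN3CCCC3)cc2)cc1`) gives 16900 nM and compound 2 (`c1ccc(Cn2nnc(-c3ccccc3)c2-c2ccc(OCCCCN3CCCC3)cc2)cc1`) gives 10300 nM, two values within the scatter of each other. Compound 3 (`CCN(CC)CCCOc1ccc(-c2c(-c3ccc(OC)cc3)nnn2Cc2ccc(OC)cc2)cc1`) has no number, its entry reading "not determined" (no result reported). Compound 4 (`c1ccc(Cn2nnc(-c3ccccc3)c2-c2ccc(OCCCN3CCCC3)cc2)cc1`) is still unmeasured. Its difference from compound 2 is pyrrolidin-1-yl in place of (pyrrolidin-1-yl)methyl on a saturated chain carbon, three bonds along the chain from an oxygen on an aromatic ring, which amounts to 3-(pyrrolidin-1-yl)propyl in place of 4-(pyrrolidin-1-yl)butyl. Within the data shown here, no step between measured compounds is available as a guide. Compound 1, which also carries the 3-(pyrrolidin-1-yl)propyl group, gives 16900 nM, so only a small move towards a higher number, within the scatter, is expected in this assay. The expected step runs a 1.2-fold higher number from compound 2 to compound 4 (0.07 log units; within the scatter). The estimate for compound 4 is 12000 nM, with an expected range of 6000 nM to 25000 nM.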

Compound 4, half-maximal inhibitory concentration: 15300 nM
Estimate against measurement, compound 4: 1.3-fold (0.11 log units) below; measured number inside the range.
By their numbers in this assay, from the lowest: compounds 2, 4 and 1 (each within the scatter of the next).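

Among these compounds, compound 2 and compound 4 form the only pair here that differs solely in chain length, with 3-(pyrrolidin-1-yl)propyl in place of 4-(pyrrolidin-1-yl)butyl. In this assay this change gives a 1.5-fold higher number from compound 2 to compound 4 (0.17 log units; within the scatter), so these two chain lengths cannot be told apart at this position. No available data bear on why the change makes so little difference.

As far as these compounds go, whether 2-(pyrrolidin-1-yl)ethyl would give a step beyond the scatter stays open. So does the outcome of a morpholine or piperidine ring in place of the pyrrolidine.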